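From Propylcarbonyl to Acetyl on the Shared Core

The compounds below may be only part of what the source reports. "The series", "measured", "known", "first", "only" and "open" are said of these compounds alone.

Of the compounds shown here, three sharing one core have been measured in a functional assay on SiHa cells (Homo sapiens) for inhibition; a higher number here means a weaker inhibitor, a lower number a stronger inhibitor. Compound 1 `COc1cc(/C=C/C(=O)c2cccc(N)c2)ccc1O`, with hydrogen on the nitrogen, gives 12.3 ug/mL. Compound 2 `COC(=O)C(=O)Nc1cccc(C(=O)/C=C/c2ccc(O)c(OC)c2)c1` gives 7.71 ug/mL, and compound 3 `CCCC(=O)Nc1cccc(C(=O)/C=C/c2ccc(O)c(OC)c2)c1` gives 3.94 ug/mL. Compound 3 has the lowest number of the three, but it is clearly separated only from compound 1, as a 3.1-fold lower number from compound 1 to compound 3 (0.49 log units; beyond the scatter) shows. It cannot be told apart from compound 2, given a 2.0-fold lower number from compound 2 to compound 3 (0.29 log units; within the scatter), and a 1.6-fold lower number from compound 1 to compound 2 (0.20 log units; within the scatter) likewise stays unresolved.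

The next compound is compound 4 `COc1cc(/C=C/C(=O)c2cccc(NC(C)=O)c2)ccc1O`. Its difference from compound 3 is hydrogen in place of ethyl on a saturated chain carbon bound to a carbonyl carbon. In other words, hydrogen stands in place of ethyl on a saturated chain carbon bound to a carbonyl carbon, so propylcarbonyl becomes acetyl. Among the compounds with values here, no measured step changes this chain alone. The nearest evidence is the modest step that installs propylcarbonyl on the nitrogen of compound 1, a 3.1-fold lower number from compound 1 to compound 3 (0.49 log units; beyond the scatter). Acetyl is expected to retain part of that gain, which points to a small move toward a higher number in this assay, probably not beyond the scatter. The expected change is a 1.5-fold higher number from compound 3 to compound 4 (0.18 log units; within the scatter). For compound 4 the estimate is 6 ug/mL, with an expected range from 3 ug/mL to 12 ug/mL.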

Compound 4, half-maximal inhibitory concentration: 15.8 ug/mL
Estimate against measurement, compound 4: 2.6-fold (0.42 log units) below; measured number above the stated range.
By their numbers in this assay, from the lowest: compounds 3, 2, 1 and 4 (each within the scatter of the next, the first and the last beyond it).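

Cutting propylcarbonyl back to acetyl is a resolved step in this assay, a 4.0-fold higher number from compound 3 to compound 4 (0.60 log units; beyond the scatter), whereas putting acetyl on the nitrogen of the shared core gives a 1.3-fold higher number from compound 1 to compound 4 (0.11 log units; within the scatter), so compound 4 cannot be told apart from compound 1. Acylation of the nitrogen therefore does not by itself account for the lower number of compound 3; among the compounds shown, that number appears only with propyl on the carbonyl carbon, and the ethyl removed in this change proves to matter at this position. The group on that carbonyl carbon also separates compound 2 from compound 4, with methyl in place of methoxycarbonyl giving a 2.0-fold higher number from compound 2 to compound 4 (0.31 log units; beyond the scatter), but nothing available explains either difference.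

The compounds shown leave open how the number behaves with an ethyl or butyl chain on the carbonyl carbon, and so whether a longer chain would extend the step seen with propyl. They also leave open whether a branched chain such as isopropyl, or a ring such as cyclopropyl, would match propyl there.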